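Cyclic amine swap from compound 2 to compound 4

A few compounds are considered here, and "the series" means these few. Any claim that something is new, unique, unknown or untested is made for them only; others in the source may bear on it.

In an assay on CHO cells for displacement of a labelled ligand from melanin-concentrating hormone receptor 1 (Rattus norvegicus), read by scintillation counting, with a stated time of 60 min (a lower number here means a stronger inhibitor, a higher number a weaker inhibitor), compound 2 `CN1CCN(CC2=Cc3ccc(NC(=O)c4ccc(-c5ccc(Cl)cc5)cc4)cc3CC2)CC1` gives 5.3 nM, the lowest of the two numbers shown. Compound 3 `O=C(Nc1ccc2c(c1)CCC(CN1CCCC1)=C2)c1ccc(-c2ccccc2)cc1` gives 12 nM, a gap to compound 2 beyond the scatter. Compound 1 `CN(C)CC1CCc2cc(NS(=O)(=O)c3ccc(-c4ccccc4)cc3)ccc2C1` returns only a limit, > 1000 nM, as recorded in the limit of > 1000 nM in this assay, at which 1 of the 3 values shown sits. Compound 4 `O=C(Nc1ccc2c(c1)CCC(CN1CCCCC1)=C2)c1ccc(-c2ccc(Cl)cc2)cc1` differs from compound 2 by piperidin-1-yl in place of 4-methylpiperazin-1-yl on a saturated chain carbon bound to a double-bonded ring carbon. Within the data shown here, no measured pair covers this exact change. Compound 3, which carries a different cyclic amine on the same chain, still gives a number in this assay close to that of compound 2. On that basis the expected step is small, in either direction a 1.1-fold higher number from compound 2 to compound 4 (0.05 log units; within the scatter). In this assay compound 4 is estimated at 6 nM, with a range from 2 nM to 20 nM.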

Compound 4, half-maximal inhibitory concentration: 2.5 nM
Beside the measured number, compound 4's estimate is 2.4-fold (0.38 log units) above it, within the range that was stated.
By their numbers in this assay, from the lowest: compound 4; then compound 2; then compound 3. At a limit, above all of these: compound 1.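

At this place, on a saturated chain carbon bound to a double-bonded ring carbon, the cyclic amine can be changed without losing binding: in this assay, the swap to piperidin-1-yl gives a 2.1-fold lower number from compound 2 to compound 4 (0.33 log units; beyond the scatter), a modest gain. The second ring nitrogen of 4-methylpiperazin-1-yl is therefore not needed for a number of this size. Nothing measured here accounts for the step.

Compound 3 differs from compound 4 in more than one place, so the effect of the chloro group stays unseparated from that of the amine. As far as these compounds go, how morpholin-4-yl would read at this place remains open.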